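The source may hold more compounds than are shown below. What is called first, only, known or untested is meant among the compounds shown, and "the series" means these compounds.

Measured in an ADME assay on a cell-free system (plasma, Rattus norvegicus) for protein binding:
- compound 1 `CO[C@H](C)c1c(NC(=O)Nc2cnc(-n3nccn3)c(Cl)c2)cnc2cc(Cl)nn12`: 96.8%
- compound 2 `O=C(Nc1cnc(-n2nccn2)c(Cl)c1)Nc1cnc2cc(Cl)nn2c1C1CC1`: 98.7%

Compound 1 has the larger unbound fraction of the two measured compounds. Compound 3 `COCc1c(NC(=O)Nc2cnc(-n3nccn3)c(Cl)c2)cnc2cc(Cl)nn12` is still unmeasured. Its difference is hydrogen in place of methyl on a saturated chain carbon bound to an aromatic carbon and an oxygen on a saturated carbon, that is, 1-methoxyethyl to methoxymethyl.

Among the compounds with values here, only one measured step bears on this: a 2.5-fold lower unbound fraction from compound 1 to compound 2 (0.39 log units; beyond the scatter), a modest step beyond the scatter, with cyclopropyl in place of 1-methoxyethyl. It replaces the whole group, whereas the new change removes only the methyl, so it is a loose guide. A smaller step is expected, leaning towards more free compound and possibly within the scatter. The expected step is a 1.3-fold higher unbound fraction from compound 1 to compound 3 (0.12 log units; within the scatter). For compound 3 the estimated value in this assay is 95.8%, with an expected range of 92.5% to 97.8%.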

Compound 3, plasma protein binding: 96.5%
Compound 3: the middle estimate sits 1.2-fold (0.08 log units) (unbound fraction) above what was measured, and the stated range covers the measured number.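

In this assay, 1-methoxyethyl and methoxymethyl read alike on the core of compound 1 (a 1.1-fold higher unbound fraction from compound 1 to compound 3 (0.04 log units; within the scatter)), so the methyl on this saturated chain carbon can go without a step beyond the scatter. Methoxymethyl in place of cyclopropyl gives a step beyond the scatter (a 2.7-fold higher unbound fraction from compound 2 to compound 3 (0.43 log units; beyond the scatter)), so among these three compounds, compound 2 stands apart from the two that carry a methoxy-bearing chain. Nothing available explains either step.

Open, on these data alone, is whether the ether oxygen matters in itself, which a comparison of methoxymethyl with a plain ethyl or a hydroxymethyl group would address. Also open, as far as these compounds go, is how a longer chain or an amine on this aromatic carbon would read in this assay.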